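The compounds below may be only part of what the source reports. "The series", "measured", "known", "first", "only" and "open" are said of these compounds alone.

In a functional assay on HepG2 cells (Homo sapiens) for antiproliferative activity, read by CCK-8 assay, with a stated time of 48 h (on this read-out lower numbers stand for stronger inhibition and higher numbers for weaker inhibition), the formyl compound 1 `COc1ccc(/C=C\c2cc(OC)c(OC)c(OC)c2)cc1OCc1ccc(C=O)cc1` gives 800 nM. Compound 2 `COc1ccc(/C=C\c2cc(OC)c(OC)c(OC)c2)cc1OCc1ccc(CN2C[C@H](O)C[C@@H]2C(=O)O)cc1` reports only a limit, > 10000 nM. Compound 3 `COc1ccc(/C=C\c2cc(OC)c(OC)c(OC)c2)cc1OCc1ccc(CN2CCCC[C@@H]2C(=O)O)cc1` also reports only a limit, > 10000 nM. Compound 4 `COc1ccc(/C=C\c2cc(OC)c(OC)c(OC)c2)cc1OCc1ccc(CN[C@H](C(=O)O)[C@H](C)O)cc1` changes the group on a saturated chain carbon bound to an aromatic carbon: (1-carboxy-2-hydroxypropyl)amino in place of 2-carboxypiperidin-1-yl on a saturated chain carbon bound to an aromatic carbon. The bearing steps are an at least 12-fold higher number from compound 1 to compound 2 (1.09 log units; beyond the scatter) and an at least 12-fold higher number from compound 1 to compound 3 (1.09 log units; beyond the scatter), both large and both ending at a limit, while a step that the two limits leave unreadable from compound 2 to compound 3 gives no size. Compound 4 also carries a carboxy group at this place, so no return towards compound 1 is expected in this assay, and no readable step in either direction. The expected step is a step that the limit leaves unreadable from compound 3 to compound 4. For compound 4 the estimated value is 14000 nM, within 5000 nM to 40000 nM.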

Compound 4, half-maximal inhibitory concentration: > 10000 nM
Compound 4: no number, only a limit (the forecaster's own chance of this, stated with the estimate: 75%); the middle value is on the limit's open side.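

At this place on the shared core, an open-chain replacement fares no better than the two ring-bearing ones: with ((1-carboxy-2-hydroxypropyl)amino)methyl in place of formyl, this assay shows an at least 12-fold higher number from compound 1 to compound 4 (1.09 log units; beyond the scatter). The steps among compound 2, compound 3 and compound 4 cannot be read, and the open-chain and ring replacements stay unranked: the limit of > 10000 nM in this assay, at which 3 of the 4 values shown sit.

From the compounds shown here alone, it remains open whether the amine or the carboxylic acid goes with the loss, as all three replacements carry both. A methyl ester or a simple amine at this place would separate the two.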